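Amide-nitrogen substituent swaps on a shared core

The source may report more compounds than this note shows. Statements on the series, on what has been measured and on what is new or still open speak of the compounds shown alone.

The three measured compounds share one core and differ only in the group on the amide-type nitrogen. In an assay on isolated protein for inhibition of histone deacetylase 4 (Homo sapiens), with a stated time of 1 h (on this read-out higher numbers stand for weaker inhibition and lower numbers for stronger inhibition), compound 1 `O=C(COc1ccc2cc(/C=C3/SC(=O)NC3=O)ccc2c1)Nc1cccc(F)n1` gives 840 nM, compound 2 `O=C(COc1ccc2cc(/C=C3/SC(=O)NC3=O)ccc2c1)Nc1ccc([N+](=O)[O-])cc1` gives 1700 nM and compound 3 `Cc1cccc2sc(NC(=O)COc3ccc4cc(/C=C5/SC(=O)NC5=O)ccc4c3)nc12` gives 1200 nM. Compound 3 stands second highest of the three numbers; one of its neighbouring steps is a 1.4-fold lower number from compound 2 to compound 3 (0.15 log units; within the scatter) and the other is a 1.4-fold higher number from compound 1 to compound 3 (0.15 log units; within the scatter), so compound 3 sits within the scatter of both neighbours. For the measured compounds named here, the only step beyond the scatter is a 2.0-fold higher number from compound 1 to compound 2 (0.31 log units; beyond the scatter).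

Compound 4 `Cc1ccc(NC(=O)COc2ccc3cc(/C=C4/SC(=O)NC4=O)ccc3c2)cc1Cl` is not yet measured. The change from compound 3 reads (3-chloro-4-methylphenyl in place of 4-methyl-1,3-benzothiazol-2-yl on an amide-type nitrogen). Going by the values given here, the closest measured precedent is the exchange between compound 2 and compound 3, a substituted phenyl against the benzothiazolyl group, which gave a 1.4-fold lower number from compound 2 to compound 3 (0.15 log units; within the scatter); the exchange from compound 1 to compound 2 gave a 2.0-fold higher number from compound 1 to compound 2 (0.31 log units; beyond the scatter), the one modest step in the set. A phenyl in place of the benzothiazolyl group thus moved the number by no more than the scatter. Compound 4 is therefore expected to show no step beyond the scatter, no change at the digits printed from compound 3 to compound 4 (within the scatter). In this assay compound 4 is estimated at 1200 nM, with a range from 500 nM to 3000 nM.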

Compound 4, half-maximal inhibitory concentration: 1100 nM
Beside the measured number, compound 4's estimate is 1.1-fold (0.04 log units) above it, within the range that was stated.
By their numbers in this assay, from the lowest: compounds 1, 4, 3 and 2 (each within the scatter of the next, the first and the last beyond it).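

At the amide-type nitrogen, 3-chloro-4-methylphenyl in place of 4-methyl-1,3-benzothiazol-2-yl gives a 1.1-fold lower number from compound 3 to compound 4 (0.04 log units; within the scatter) in this assay, so this exchange removes the five-membered aromatic ring and both hydrogen-bond acceptors counted for the leaving group without a step beyond the scatter. For the compounds shown here, the other two new steps, a 1.5-fold lower number from compound 2 to compound 4 (0.19 log units; within the scatter) and a 1.3-fold higher number from compound 1 to compound 4 (0.12 log units; within the scatter), also stay within the scatter, which places compound 4 within reach of every earlier compound, while the only step beyond it remains a 2.0-fold higher number from compound 1 to compound 2 (0.31 log units; beyond the scatter) in the same assay. No supporting data bear on this result, so the close agreement among these groups remains without an explanation.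

The compounds shown all carry an aromatic ring directly on the amide-type nitrogen, which leaves open whether the read-out stays this close with a cyclohexyl group, a longer chain such as 2-phenylethyl, or a phenyl carrying a carboxylic acid or an amine. Going by these compounds alone, they also leave open whether a change at this nitrogen can move the number much further than the one modest step seen so far.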